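The source may report more compounds than this note shows. Statements on the series, on what has been measured and on what is new or still open speak of the compounds shown alone.

In a functional assay on SUP-B15 cells (Homo sapiens) for antiproliferative activity, with a stated time of 72 h (on this read-out lower numbers stand for an effect already at smaller amounts and higher numbers for an effect only at larger amounts of compound), compound 1 `COc1ccc(-c2cc(=O)c3c(OC)cc(OC)cc3n2C)cc1` gives 28000 nM. Compound 2 `COc1ccc(-c2cc(=O)c3c(OC)cc(OC)cc3n2S(=O)(=O)c2ccc(C=O)cc2)cc1` reaches only a limit of this assay, > 34400 nM. Compound 3 `COc1ccc(-c2cc(=O)c3c(OC)cc(OC)cc3n2S(=O)(=O)c2cc(Cl)cc(Cl)c2O)cc1` likewise gives only a limit, > 37900 nM.

Compound 3 therefore stands at a limit rather than at a number, as does compound 2, so the step that the two limits leave unreadable from compound 2 to compound 3 cannot be read. For the measured compounds named here, the one readable step, an at least 1.2-fold higher number from compound 1 to compound 2 (0.08 log units; that floor lies within the scatter), shows that replacing the methyl on the aromatic nitrogen with a sulfonyl group did not make the effect appear at smaller amounts. Compound 4 `COc1ccc(-c2cc(=O)c3c(OC)cc(OC)cc3n2S(=O)(=O)c2ccc(Br)cc2)cc1` carries the change (4-bromophenyl in place of 3,5-dichloro-2-hydroxyphenyl on a sulfonyl sulfur). With both sulfonyl compounds sitting at limits, compound 4 is expected to remain near or at a limit too, a step that the limit leaves unreadable from compound 3 to compound 4 expected to stay within the scatter. Compound 4 is estimated at 40000 nM, within 18000 nM to 100000 nM.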

Compound 4, half-maximal effective concentration: 63800 nM
The estimate for compound 4 lay 1.6-fold (0.20 log units) below the measured number, and the stated range covers the measured number.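

For the compounds shown here, compound 4 is the one sulfonyl compound here with a real number rather than a limit, so the change on the aromatic nitrogen can now be sized in this assay. Putting (4-bromophenyl)sulfonyl in place of methyl gives a 2.3-fold higher number from compound 1 to compound 4 (0.36 log units; beyond the scatter), so the effect needs somewhat larger amounts of compound. The steps to compound 4 from compound 2 and from compound 3 cannot be read: those two compounds give only limits.

Going by these compounds, it stays open how a plain ethyl group on the aromatic nitrogen would compare. On these data alone, it is also open whether an amine or a carboxylic acid on the sulfonyl's phenyl ring would shift the number.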